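Methyl on the Anilino Ring of Compound 1

This account rests on a few compounds, and the source may have more. Where it says the series, first, only, none or still open, it means among the compounds named here.

Measured so far in a functional assay on BGC-823 cells (Homo sapiens) for cytotoxicity, read by MTT assay; on this read-out lower numbers stand for stronger inhibition and higher numbers for weaker inhibition:
compound 1 `COc1cccc(/C=C/C(=O)c2sc(Nc3ccccc3)nc2C)c1` — 14300 nM
compound 2 `Cc1nc(Nc2ccccc2)sc1C(=O)/C=C/c1ccc(Cl)cc1` — > 25000 nM, which is a limit of the assay and not a number
compound 3 `Cc1nc(Nc2ccccc2)sc1C(=O)/C=C/c1ccccc1` — 19500 nM

Compound 1 holds the lowest of the two numbers in this assay. Its nearest neighbour is compound 3, reached by a 1.4-fold higher number from compound 1 to compound 3 (0.13 log units; within the scatter), a step that removes the methoxy group from the aromatic ring. The value of compound 2 is a limit of the assay, as given in the limit of > 25000 nM in this assay, at which 1 of the 3 values shown sits. From compound 1 to compound 2 the step reads an at least 1.7-fold higher number from compound 1 to compound 2 (0.24 log units; that floor lies within the scatter), and from compound 2 to compound 3 it reads an at least 1.2-fold lower number from compound 2 to compound 3 (0.10 log units; that floor lies within the scatter). All three measured steps change the ring on the double-bonded chain; none of them touches the anilino side of the shared core.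

Compound 4 `COc1cccc(/C=C/C(=O)c2sc(Nc3ccccc3C)nc2C)c1` differs from compound 1 by methyl in place of hydrogen on an aromatic carbon, a methyl in place of hydrogen on an aromatic carbon of the anilino ring, ortho to a large group. For the measured compounds named here, no measured step bears directly on this change. Compound 4 is therefore expected to give 14000 nM in this assay, within a range from 5000 nM to 40000 nM. That estimate means a step of a 1.0-fold lower number from compound 1 to compound 4 (0.01 log units; within the scatter), expected to stay within the scatter.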

Compound 4, half-maximal inhibitory concentration: > 25000 nM
Compound 4: no number, only a limit (the forecaster's own chance of this, stated with the estimate: 25%); at least 1.7-fold (0.25 log units) between middle value and limit.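

In this assay compound 4 gives only a limit of the assay and not a number, the second such limit among the compounds shown: the limit of > 25000 nM in this assay, at which 2 of the 4 values shown sit. It is also the first compound shown to carry a change on the anilino side of the shared core, and methyl in place of hydrogen on this aromatic carbon, ortho to a large group, gives an at least 1.7-fold higher number from compound 1 to compound 4 (0.24 log units; that floor lies within the scatter). The result therefore shows that this small change on the anilino ring brings no measurable gain in this assay, but it does not establish a loss, as the floor of the step lies within the scatter.

The compounds shown leave open whether the true value of compound 4 lies close to that of compound 1 or far from it, and so how much this position matters to the read-out. They also leave open how a fluorine, a hydroxyl or an ethyl group would read at this place on the anilino ring, and whether a methyl on another carbon of that ring would read the same.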